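Benzenesulfonamide series: styryl in place of triazolylmethyl

The source may hold more compounds than are shown below. What is called first, only, known or untested is meant among the compounds shown, and "the series" means these compounds.

For the measured compounds named here, compound 3 `CCOC(=O)c1cn(Cc2nnc(-c3cc(S(N)(=O)=O)c(SCc4ccccc4)cc3Cl)o2)nn1` stands second highest of the three numbers so far in a functional assay on MCF7 cells (Homo sapiens) for cytotoxicity, read by MTT assay, with a stated time of 72 h (a lower number here means a stronger inhibitor, a higher number a weaker inhibitor), where compound 3 gives 150000 nM. Compound 1 `NS(=O)(=O)c1cc(-c2nnc(CN3CCN(Cc4ccccc4)CC3)o2)c(Cl)cc1SCc1ccccc1` gives 125000 nM, within the scatter of compound 3; compound 2 `NS(=O)(=O)c1cc(-c2nnc(CN3CCN(c4ccc(Cl)cc4)CC3)o2)c(Cl)cc1SCc1ccccc1` gives 280000 nM, also within the scatter of compound 3. Going by the values given here, the only single-point step measured so far, a 2.2-fold higher number from compound 1 to compound 2 (0.35 log units; beyond the scatter), concerns the group on the amine nitrogen in a ring and not the position changed here. Compound 4 `NS(=O)(=O)c1cc(-c2nnc(/C=C/c3ccccc3)o2)c(Cl)cc1SCc1ccccc1` carries 2-phenylethenyl in place of (4-(ethoxycarbonyl)-1H-1,2,3-triazol-1-yl)methyl on an aromatic carbon. Among the compounds with values here, no measured step bears on this position, so no shift beyond the scatter is expected in this assay, in either direction. Compound 4 is therefore expected to give about 130000 nM, with a range of 50000 nM to 350000 nM, meaning an expected step of a 1.2-fold lower number from compound 3 to compound 4 (0.06 log units; within the scatter).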

Compound 4, half-maximal inhibitory concentration: 16000 nM
Compound 4: middle estimate off by 8.1-fold (0.91 log units), on the high side, outside the stated range (below it).
By their numbers in this assay, from the lowest: compound 4; then compounds 1, 3 and 2 (each within the scatter of the next, the first and the last beyond it).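

In this assay, the group on this aromatic carbon of the five-membered aromatic ring proves able to move the number: 2-phenylethenyl in place of (4-(ethoxycarbonyl)-1H-1,2,3-triazol-1-yl)methyl gives a 9.4-fold lower number from compound 3 to compound 4 (0.97 log units; beyond the scatter), the first step measured at this position. The entering group is all carbon, with 0 hydrogen-bond acceptors against 5 in the group it replaces. Nothing measured here accounts for the step. Still open, from the compounds shown here alone, is whether the double bond or the phenyl ring carries the step; the saturated 2-phenylethyl chain would separate the two.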